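A few compounds are considered here, and "the series" means these few. Any claim that something is new, unique, unknown or untested is made for them only; others in the source may bear on it.

Three compounds have been measured in a functional assay on the whole organism (strain Sprague-Dawley) for inhibition, with Rattus norvegicus as the target; on this read-out lower numbers stand for an effect already at smaller amounts and higher numbers for an effect only at larger amounts of compound:

Compound 1 `COc1cccc2cc(C(=O)O)cnc12` gives 150 mg/kg.
Compound 2 `COc1cccc2cc(-c3nn[nH]n3)cnc12` gives > 25 mg/kg, which is a limit of the assay and not a number.
Compound 3 `Cc1ccc2cc(C(=O)O)cnc2c1C` gives 50 mg/kg.

Compound 1 and compound 3 differ in more than one place; the difference between their two cores is not broken down here. Of the two numbers, compound 3 stands lowest, with compound 1 the nearest value at a gap beyond the usual scatter. Compound 2 contributes only (the limit of > 25 mg/kg in this assay, at which 1 of the 3 values shown sits).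

Within the core of compound 1, one change has been made: 2H-tetrazol-5-yl in place of carboxy on an aromatic carbon. Its size, a step that the limit leaves unreadable from compound 1 to compound 2, is not readable, since compound 2 reached only the limit in this assay. The same change, (2H-tetrazol-5-yl in place of carboxy on an aromatic carbon), leads from compound 3 to the still unmeasured compound 4 `Cc1ccc2cc(-c3nn[nH]n3)cnc2c1C`; the place is described in identical words for both pairs, so it is the same change carried onto a different core.

Going by the values given here, because the measured step is a step that the limit leaves unreadable from compound 1 to compound 2, the one example gives neither direction nor size to carry over. Compound 4 is therefore expected near its parent, at about 60 mg/kg in this assay. Among the compounds with values here, compound 4 is estimated to span from 20 mg/kg to 200 mg/kg, a wide range since the only precedent ended in a limit. The step of a 1.2-fold higher number from compound 3 to compound 4 (0.08 log units; within the scatter) is expected to be modest, resting on compound 3 giving 50 mg/kg and on nothing else.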

Compound 4, minimum effective dose: 25 mg/kg
Compound 4: middle estimate off by 2.4-fold (0.38 log units), on the high side, and the stated range covers the measured number.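

In this assay, replacing carboxy with 2H-tetrazol-5-yl on the core of compound 3 gives a 2.0-fold lower number from compound 3 to compound 4 (0.30 log units; within the scatter), so the two compounds cannot be told apart on this read-out, and the change shows no effect that stands clear of the usual variation on this core. Going by these compounds alone, the same change on the core of compound 1 cannot be read, since compound 2 reached only a limit of the assay: the limit of > 25 mg/kg in this assay, at which 1 of the 4 values shown sits. This leaves a single readable example of the change, on a single core, which shows that one result but not whether it carries over from one core to the other, as no second readable pair exists to set beside it.

The compounds shown leave open how other groups on the same aromatic carbon, such as a methyl ester or a primary amide, would read in this assay beside carboxy and 2H-tetrazol-5-yl. From the compounds shown here alone, compound 1 and compound 3 differ in more than one place, so it also remains open which of those differences goes with their two values, and what a single added group on the shared core, such as a chlorine or an amine, would do.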